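Aryl substituent variation on the shared amide core

This account rests on a few compounds, and the source may have more. Where it says the series, first, only, none or still open, it means among the compounds named here.

Measured so far in a functional assay on the whole organism (integument) for inhibition, with Chilo suppressalis as the target, read by scintillation counting, with a stated time of 72 h; on this read-out lower numbers stand for stronger inhibition and higher numbers for weaker inhibition:
compound 1, `COc1cccc(OC)c1C(=O)Nc1nnc(-c2ccc(Br)cc2)s1`, gives 66.1 nM
compound 2, `COc1cccc(OC)c1C(=O)Nc1nnc(-c2ccc(C(F)(F)F)cc2)s1`, gives 49 nM

Within the data shown here, compound 2 stands at the lowest of the two numbers, yet its only neighbour, compound 1, lies within the scatter of it. Among the measured compounds shown here, the single measured step, a 1.3-fold lower number from compound 1 to compound 2 (0.13 log units; within the scatter), shows no ordering between the two. Compound 3, `COc1cccc(OC)c1C(=O)Nc1nnc(-c2ccc(-c3ccccc3)cc2)s1`, has not been measured. It differs from compound 2 by phenyl in place of trifluoromethyl on an aromatic carbon. For the measured compounds named here, the one measured step concerns a different exchange at the same position and was within the scatter, so it gives only weak guidance on a swap to phenyl; an entering six-membered aromatic ring of carbon only has no precedent among the measured compounds. With nothing bearing directly on this change, no shift beyond the scatter is expected in this assay, though the uncertainty is wide. Compound 3 is expected to give 60 nM, with a likely range from 20 nM to 200 nM. The expected step of a 1.2-fold higher number from compound 2 to compound 3 (0.09 log units; within the scatter) is estimated to stay close to the scatter.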

Compound 3, half-maximal inhibitory concentration: 195 nM
Estimate against measurement, compound 3: 3.3-fold (0.51 log units) below; the range from low to high includes it.
By their numbers in this assay, from the lowest: compounds 2 and 1 (each within the scatter of the next); then compound 3.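

In this assay, this position proves sensitive to the group it carries: phenyl in place of trifluoromethyl gives a 4.0-fold higher number from compound 2 to compound 3 (0.60 log units; beyond the scatter), whereas the earlier exchange of bromo for trifluoromethyl produced no step beyond the scatter. Phenyl in place of bromo points the same way, with a 3.0-fold higher number from compound 1 to compound 3 (0.47 log units; beyond the scatter), so both measured exchanges to phenyl raise the number, and compound 3 is the weakest inhibitor of the three, while bromo and trifluoromethyl remain indistinguishable. No supporting measurement is available to account for this loss of inhibition.

On these data alone, whether the rise belongs to the entering aromatic ring itself or simply to the greater count of heavy atoms stays open, and a cyclohexyl group or a longer alkyl chain on the same aromatic carbon would help separate the two readings. Also open is how groups of a different kind, such as an amine, a carboxylic acid or a methoxy group, would read at this place on the shared core, since the three compounds shown cover only bromo, trifluoromethyl and phenyl.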